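The source may hold more compounds than are shown below. What is called first, only, known or untested is meant among the compounds shown, and "the series" means these compounds.

Three amides built on one shared core have been tested in a functional assay on HeLa cells (Homo sapiens) for antiproliferative activity, read by MTT assay, with a stated time of 72 h; on this read-out higher numbers stand for weaker inhibition and lower numbers for stronger inhibition. Compound 1 `O=C(Nc1ccc(Cl)c(-c2nnc3c(Cl)cccn23)c1)c1ccc(Cl)cc1Cl` carries a 2,4-dichlorophenyl on the carbonyl carbon, and in this assay compound 1 reaches only a limit of the assay, > 100000 nM. Compound 2 `O=C(Nc1ccc(Cl)c(-c2nnc3c(Cl)cccn23)c1)c1c(F)cccc1Cl` carries a 2-chloro-6-fluorophenyl there, and in this assay compound 2 likewise reaches only a limit, > 100000 nM. Going by the values given here, compound 3 `O=C(Nc1ccc(Cl)c(-c2nnc3c(Cl)cccn23)c1)c1cccnc1Cl` carries a 2-chloropyridin-3-yl on the carbonyl carbon, and in this assay compound 3 gives 87500 nM, the single read number among the three. The steps of an at least 1.1-fold lower number from compound 1 to compound 3 (0.05 log units; that floor lies within the scatter) and an at least 1.1-fold lower number from compound 2 to compound 3 (0.05 log units; that floor lies within the scatter) are only floors and lie within the scatter of repeated runs, so none of the three compounds can be told apart on these numbers. The step that the two limits leave unreadable from compound 1 to compound 2 cannot be read at all because of the limit of > 100000 nM in this assay, at which 2 of the 3 values shown sit.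

Compound 4 `O=C(Nc1ccc(Cl)c(-c2nnc3c(Cl)cccn23)c1)c1ccccc1` has not yet been measured. It differs from compound 3 by phenyl in place of 2-chloropyridin-3-yl on a carbonyl carbon. The measured steps that bear on this are the two exchanges of the group on the carbonyl carbon ending at compound 3, and neither moved beyond the scatter. The expected step is a 1.0-fold higher number from compound 3 to compound 4 (0.01 log units; within the scatter), that is, no change beyond the scatter. Compound 4 is therefore estimated at 90000 nM, with a range from 30000 nM to 300000 nM, and a fair chance that only a limit is returned.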

Compound 4, half-maximal inhibitory concentration: > 100000 nM
Compound 4: no number, only a limit; the forecaster's own chance of this, stated with the estimate: 50%; at least 1.1-fold (0.04 log units) between middle value and limit.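

Going by these compounds alone, compound 4 is the first amide here whose ring on the carbonyl carbon carries no chlorine, and in this assay compound 4 gives only a limit, > 100000 nM. Taking away both the ring nitrogen and the chlorine of 2-chloropyridin-3-yl to leave phenyl gives an at least 1.1-fold higher number from compound 3 to compound 4 (0.05 log units; that floor lies within the scatter), so this exchange does not set compound 3 apart from the plain benzoyl amide, and a bare phenyl shows no measurable gain over the chlorinated rings. The steps to compound 4 from compound 1 and from compound 2 cannot be read, because each compares one limit with another: the limit of > 100000 nM in this assay, at which 3 of the 4 values shown sit.

The compounds shown cannot say whether the single read number of compound 3 owes anything to the ring nitrogen or to the chlorine, since the two leave together in this step; a pyridin-3-yl or a 2-chlorophenyl on the same carbonyl carbon would separate them. It also stays open whether any group at this place can bring a number clearly under the limit, for all four carry a simple aromatic ring there, and an amine, a carboxylic acid or a longer chain lies outside what is shown.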